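The source may hold more compounds than are shown below. What is called first, only, known or untested is meant among the compounds shown, and "the series" means these compounds.

Working notes on the series. Compound 1 `O=C(O)Cn1nc(CC(=O)Nc2ccc(OC(F)(F)F)c(Cl)c2)c2ccccc2c1=O` gives 389 nM in a functional assay on CHO cells for antagonist activity at sphingosine 1-phosphate receptor 2 (Homo sapiens), read by calcium flux; on this read-out higher numbers stand for weaker inhibition and lower numbers for stronger inhibition. Compound 3 `C[C@H](C(=O)O)c1nn(Cc2cn3cc(OCC4CC4)c(Cl)cc3n2)c2ccccc2c1=O` gives 3.2 nM in this assay. Compound 2 `COc1cc(OC)c(NC(=O)Cc2cn(C)c3ccccc23)cc1Cl` returns only > 8130 nM in this assay, a limit and not a number. Of the two numbers shown, compound 1 stands at the higher one; compound 3 sits far lower, well beyond the scatter.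

Compound 4 `O=C(Cc1nn(C2CC2)c(=O)c2ccccc12)Nc1ccc(OC(F)(F)F)c(Cl)c1` differs from compound 1 by cyclopropyl in place of carboxymethyl on an aromatic nitrogen. Among the compounds with values here, no measured pair isolates this change. Compound 2, which carries no carboxymethyl, sits at the limit, but it differs from compound 1 in more than one place, so it is only a hint. The expected change is a move toward weaker inhibition in this assay, beyond the scatter, a 6.4-fold higher number from compound 1 to compound 4 (0.81 log units; beyond the scatter). Compound 4 is expected at 2500 nM, between 600 nM and 8130 nM.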

Compound 4, half-maximal inhibitory concentration in the sphingosine 1-phosphate receptor 2 assay: 218 nM
For compound 4 the middle estimate is 11-fold (1.06 log units) above the measured one, and the stated range ends above it.
By their numbers in the sphingosine 1-phosphate receptor 2 assay, from the lowest: compound 3; then compounds 4 and 1 (each within the scatter of the next). At a limit, above all of these: compound 2.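

In the sphingosine 1-phosphate receptor 2 assay, cyclopropyl in place of carboxymethyl on the aromatic nitrogen gives a 1.8-fold lower number from compound 1 to compound 4 (0.25 log units; within the scatter), so inhibition at this level does not depend on the carboxymethyl in this pair. Within the data shown here, in a physicochemical assay for lipophilicity, at pH 7.4 (a higher number here means a more lipophilic compound, a lower number a more polar compound), compound 1 gives 2.92 and compound 4 gives 5.43, a gap beyond the scatter that has no counterpart in inhibition. Among these compounds, this position therefore separates the distribution coefficient from inhibition, which the earlier compounds could not show. From the compounds shown here alone, whether an amine or a hydroxyethyl chain on this nitrogen would keep inhibition at this level with a lower distribution coefficient remains open.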